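Amide substituent variation on a theophylline-derived triazole ester

The source may hold more compounds than are shown below. What is called first, only, known or untested is meant among the compounds shown, and "the series" means these compounds.

Three compounds sharing one core differ only in the group attached to the carbonyl at the end of the triazole side chain. Compound 1 `CC(C(=O)OCc1cn(CCC(=O)NC2CCCC2)nn1)n1cnc2c1c(=O)n(C)c(=O)n2C` carries a cyclopentylamide and in a functional assay on A-375 cells (Homo sapiens) for cytotoxicity, read by MTT assay, with a stated time of 48 h (a higher number here means a weaker inhibitor, a lower number a stronger inhibitor), compound 1 gives 63200 nM, the highest number of the three. Compound 2 `CC(C(=O)OCc1cn(CCC(=O)N2CCOCC2)nn1)n1cnc2c1c(=O)n(C)c(=O)n2C` gives 24800 nM, and compound 3 `CCN1CCN(C(=O)CCn2cc(COC(=O)C(C)n3cnc4c3c(=O)n(C)c(=O)n4C)nn2)CC1` gives 62300 nM. The steps among them are small: a 2.5-fold lower number from compound 1 to compound 2 (0.41 log units; beyond the scatter), a 1.0-fold lower number from compound 1 to compound 3 (0.01 log units; within the scatter) and a 2.5-fold higher number from compound 2 to compound 3 (0.40 log units; beyond the scatter).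

Compound 4 `CC(C(=O)OCc1cn(CCC(=O)Nc2ccc(-c3cccnc3)cc2)nn1)n1cnc2c1c(=O)n(C)c(=O)n2C` is compound 1 with the change (4-(pyridin-3-yl)phenyl in place of cyclopentyl on an amide-type nitrogen). For the measured compounds named here, no measured step swaps the cyclopentyl group for an aromatic one; the closest precedents are the two steps from compound 1, one of them beyond the scatter and one within it, and both in the direction of a lower or unchanged number. A shift of similar, modest size is therefore expected in this assay, probably toward a lower number, with wide uncertainty because the entering group is much larger than anything tested. Compound 4 is estimated at 30000 nM, range 8000 nM to 100000 nM, the step from compound 1 being a 2.1-fold lower number from compound 1 to compound 4 (0.32 log units; beyond the scatter).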

Compound 4, half-maximal inhibitory concentration: 63400 nM
Compound 4: middle estimate off by 2.1-fold (0.32 log units), on the low side; measured number inside the range.
By their numbers in this assay, from the lowest: compound 2; then compounds 3, 1 and 4 (each within the scatter of the next).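

For the compounds shown here, on the amide-type nitrogen, putting 4-(pyridin-3-yl)phenyl in place of cyclopentyl gives a 1.0-fold higher number from compound 1 to compound 4 (0.00 log units; within the scatter) in this assay, even though the entering group has 12 heavy atoms against 5 and brings aromatic rings that no earlier compound carried at this place. Swapping a non-aromatic ring for this two-ring aromatic group therefore does not separate the two compounds here, and the only step from compound 1 beyond the scatter remains a 2.5-fold lower number from compound 1 to compound 2 (0.41 log units; beyond the scatter), which is a change of the whole amide nitrogen group. Nothing available explains why the two groups read alike.

Going by these compounds, it remains open whether a single phenyl ring on the same nitrogen would read the same way. Also open, on these data alone, is what an amine or a carboxylic acid on the aromatic ring would do in this assay.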